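A Methyl Group Leaves at the Assay Limit

A few compounds are considered here, and "the series" means these few. Any claim that something is new, unique, unknown or untested is made for them only; others in the source may bear on it.

In an ADME assay on L1210/0 cells (Mus musculus) for cytotoxicity, with a stated time of 48 h (on this read-out higher numbers stand for weaker inhibition and lower numbers for stronger inhibition), compound 1 (`COC1=C(OCc2ccc([N+](=O)[O-])cc2)C(=O)O/C1=C\Cn1cnc2c(Cl)ncnc21`) gives 13600 nM as a measured number. For compound 2 (`CN(C)c1nc2c(=O)[nH]c(N)nc2n1COCCO`) there is only a limit (> 200000 nM) and no number, which is the limit of > 200000 nM in this assay, at which 1 of the 2 values shown sits, here. Compound 3 (`CNc1nc2c(=O)[nH]c(N)nc2n1COCCO`) carries hydrogen in place of methyl on a nitrogen on an aromatic ring and so turns dimethylamino to methylamino. Among the measured compounds shown here, no measured pair shows this change in this assay and no step beyond the scatter is expected. The expected step, an at least 1.1-fold lower number from compound 2 to compound 3 (0.04 log units; that floor lies within the scatter), is estimated without direction. Compound 3 is expected near 180000 nM with an estimated range of 90000 nM to 400000 nM and might also return only a limit.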

Compound 3, half-maximal inhibitory concentration: > 200000 nM
Compound 3: no number, only a limit (the forecaster's own chance of this, stated with the estimate: 65%); at least 1.1-fold (0.04 log units) between middle value and limit.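

In this assay compound 3 gives > 200000 nM, a limit and not a number. Compound 2 also sits at a limit, and no step can be read between compound 2 and compound 3. The compounds shown leave open what hydrogen in place of methyl does on this read-out.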